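The source may report more compounds than this note shows. Statements on the series, on what has been measured and on what is new or still open speak of the compounds shown alone.

Measured compounds:
- compound 1, `N/C(=N/O)c1ccc2[nH]c(-c3cccc(-c4ccccc4O)c3O)cc2c1`: 380000 nM in a physicochemical assay for solubility, in phosphate buffer, at pH 7.4; on this read-out lower numbers stand for lower solubility and higher numbers for higher solubility
- compound 2, `C=CCO/N=C(/N)c1ccc2[nH]c(-c3cccc(-c4ccccc4O)c3O)cc2c1`: compound 2 gives 24000 nM in this assay
- compound 3, `CCOC(=O)NC(=N)c1ccc2[nH]c(-c3cccc(-c4ccccc4O)c3O)cc2c1`: compound 3 gives only a limit, < 10000 nM, in this assay

Compound 1 has the highest of the two numbers in this assay; the nearest is compound 2, and the third value is a limit, as noted in the limit of < 10000 nM in this assay, at which 1 of the 3 values shown sits.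

Compound 4, `CC(C)OC(=O)NC(=N)c1ccc2[nH]c(-c3cccc(-c4ccccc4O)c3O)cc2c1`, is not yet measured. It differs from compound 1 by a group of 9 heavy atoms (5 carbon, 2 nitrogen, 2 oxygen; no ring) in place of a group of 4 heavy atoms (1 carbon, 2 nitrogen, 1 oxygen; no ring), on an aromatic carbon.

Two measured steps start from compound 1. Replacing hydrogen on an oxygen by allyl gave a 16-fold lower number from compound 1 to compound 2 (1.20 log units; beyond the scatter). The heavier change at the same aromatic carbon gave an at least 38-fold lower number from compound 1 to compound 3 (1.57 log units; beyond the scatter), ending at the limit. Between the two elaborated compounds, an at least 2.4-fold lower number from compound 2 to compound 3 (0.38 log units; beyond the scatter). The change to compound 4 is of the same kind as that to compound 3, with one more carbon entering, so a large drop in this assay is expected, likely to or beyond the limit.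

Compound 4 is expected at 5000 nM, within 1500 nM to 12000 nM. This estimate corresponds to a 76-fold lower number from compound 1 to compound 4 (1.88 log units; beyond the scatter).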

Compound 4, solubility: < 10000 nM
Compound 4: a limit, no number; the forecaster's own chance of this, stated with the estimate: 70%; the middle value does not contradict the limit.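

In this assay, compound 4 returns a limit and not a number, placing a second compound at the bottom of the readable range: the limit of < 10000 nM in this assay, at which 2 of the 4 values shown sit.

Exchanging the group of 4 heavy atoms on the aromatic carbon for the group of 9 heavy atoms gives an at least 38-fold lower number from compound 1 to compound 4 (1.57 log units; beyond the scatter), and exchanging the group of 7 heavy atoms for the same group gives an at least 2.4-fold lower number from compound 2 to compound 4 (0.38 log units; beyond the scatter), so the low end of the series now holds for both compound 3 and compound 4, and neither bound is a measured size. On these data alone, with both of those compounds at the limit, the step between them cannot be read, and the effect of methyl in place of hydrogen on the saturated chain carbon remains unknown.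

As far as these compounds go, how far compound 3 and compound 4 lie beyond the limit in this assay stays open, and so does any order between them. Also open, from the compounds shown here alone, is whether a longer chain on the same oxygen stays at the limit, or whether a terminal amine or carboxylic acid on that chain returns a readable number.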